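The compounds below may be only part of what the source reports. "The series", "measured", "known", "first", "only" and "open" are said of these compounds alone.

Measured so far in a functional assay on HeLa cells (Homo sapiens) for cytotoxicity, read by MTT assay, with a stated time of 48 h; on this read-out higher numbers stand for an effect only at larger amounts of compound and lower numbers for an effect already at smaller amounts
Compound 1 `CO[C@H]1O[C@H](COc2ccc(-c3ccccc3)cc2)[C@@H](O)[C@H](O)[C@H]1Oc1ccccc1` gives 33000 nM
Compound 2 `CO[C@H]1O[C@H](COc2ccc3c(c2)CCCC3)[C@@H](O)[C@H](O)[C@H]1Oc1cccc(C(C)C)c1` gives 33000 nM
Compound 3 `CO[C@H]1O[C@H](COc2ccc(C3CCCCC3)cc2)[C@@H](O)[C@H](O)[C@H]1Oc1ccc(OC2CCCCC2)cc1` gives 10000 nM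

Compound 1 stands level with compound 2, together the highest of the three numbers, and compound 3 lies lower, beyond the scatter. Compound 4 `CO[C@H]1O[C@H](COc2ccc(-c3ccccc3)cc2)[C@@H](O)[C@H](O)[C@H]1Oc1ccccc1C(C)C` differs from compound 1 by isopropyl in place of hydrogen on an aromatic carbon, ortho to a large group, so that phenoxy becomes 2-isopropylphenoxy (isopropyl in place of hydrogen on an aromatic carbon). Going by the values given here, no measured pair differs in one place only. Compound 2 also carries an isopropyl and gives 33000 nM, level with compound 1. A small move toward a lower number in this assay, within the scatter, is therefore expected (a 1.3-fold lower number from compound 1 to compound 4 (0.12 log units; within the scatter)). For compound 4 the estimated value is 25000 nM (expected range 10000 nM to 60000 nM).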

Compound 4, half-maximal effective concentration: 29000 nM
Beside the measured number, compound 4's estimate is 1.2-fold (0.06 log units) below it; the range from low to high includes it.
By their numbers in this assay, from the lowest: compound 3; then compounds 4, 1 and 2 (each within the scatter of the next).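

In this assay, going by these compounds alone, isopropyl in place of hydrogen on an aromatic carbon, ortho to a large group, gives a 1.1-fold lower number from compound 1 to compound 4 (0.06 log units; within the scatter), the only step so far that differs in one place. Turning phenoxy into 2-isopropylphenoxy therefore leaves the number within the scatter, so this place accepts isopropyl without a readable change in this read-out. No measured evidence bears on this result.

Going by these compounds, whether an amine or a carboxylic acid in the same place would move the number remains open. So does whether a longer chain there would behave as isopropyl does.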